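Dropping the chain methyl from compound 2

The source may hold more compounds than are shown below. What is called first, only, known or untested is meant among the compounds shown, and "the series" means these compounds.

In a functional assay on CCRF-CEM cells (Homo sapiens) for antiproliferative activity, read by trypan blue exclusion, with a stated time of 72 h (on this read-out lower numbers stand for stronger inhibition and higher numbers for weaker inhibition), three compounds are measured so far: compound 1 (`Cc1ccc(NC(=O)C(C)Br)cc1C(=O)NC(N)=O`), compound 2 (`CC(Br)C(=O)Nc1ccc(F)c(C(=O)NC(N)=O)c1`) and compound 3 (`CC(Br)C(=O)Nc1ccc(Cl)c(C(=O)NC(N)=O)c1`). Compound 1 stands at a limit of the assay (> 20000 nM) and gives no number. Compound 2 (520 nM) holds the lower of the two actual numbers, ahead of compound 3 (2550 nM).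

The next compound is compound 4 (`NC(=O)NC(=O)c1cc(NC(=O)CBr)ccc1F`), and the change from compound 2 is hydrogen in place of methyl on a saturated chain carbon bound to a bromine atom and a carbonyl carbon in all. This is hydrogen in place of methyl on a saturated chain carbon bound to a bromine atom and a carbonyl carbon, so 1-bromoethyl becomes bromomethyl.

All three measured steps sit on an aromatic carbon: the large fluoro for methyl step (an at least 38-fold lower number from compound 1 to compound 2 (1.58 log units; beyond the scatter)), the chloro for methyl step (an at least 7.8-fold lower number from compound 1 to compound 3 (0.89 log units; beyond the scatter)) and the modest chloro for fluoro step (a 4.9-fold higher number from compound 2 to compound 3 (0.69 log units; beyond the scatter)). They show that small changes can move this series, but none touches the chain carbon, so none gives a size or direction here. No shift beyond the scatter is therefore expected, though with wide uncertainty. The expected step is small (a 1.3-fold lower number from compound 2 to compound 4 (0.11 log units; within the scatter)) on this basis. For compound 4 the estimated value is 400 nM in a range of 100 nM to 1600 nM as expected from these data.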

Compound 4, half-maximal inhibitory concentration: < 10 nM
Compound 4: a limit, no number (the forecaster's own chance of this, stated with the estimate: 5%); middle value at least 40-fold (1.60 log units) from the limit.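

The chain carbon bound to a bromine atom and a carbonyl carbon, which none of the aromatic steps touched, proves a highly sensitive place in this assay: going from 1-bromoethyl to bromomethyl moves the read-out strongly towards inhibition (an at least 52-fold lower number from compound 2 to compound 4 (1.71 log units; beyond the scatter)). This change removes a single carbon and brings in no heavy atom, yet the step is larger than the chloro for fluoro step on the aromatic carbon (a 4.9-fold higher number from compound 2 to compound 3 (0.69 log units; beyond the scatter)), so the methyl on this carbon is not needed for activity, and in this pair its loss goes with much stronger inhibition. Compound 4 stands at a limit of the assay, so the full size of its step stays open: the limit of < 10 nM in this assay, at which 1 of the 4 values shown sits.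

Open, going by these compounds, is whether the same step holds with chloro or methyl on the aromatic carbon, as in compound 3 and compound 1, since this single pair carries fluoro only. Also open, on these data alone, is how far the chain carbon tolerates other groups, such as chloromethyl in place of bromomethyl, a plain acetyl group without the halogen, or a longer chain such as 1-bromopropyl.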